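From compound 3 to compound 4: a shorter side chain

The compounds below may be only part of what the source reports. "The series", "measured", "known", "first", "only" and "open" are said of these compounds alone.

In a functional assay on DU-145 cells (Homo sapiens) for cytotoxicity, read by MTT assay (a lower number here means a stronger inhibitor, a higher number a weaker inhibitor), compound 3 `CCCCCCC(C)(O)CC(=O)O[C@H](CC=C(C)C)C1=CC(=O)c2c(O)ccc(O)c2C1=O` gives > 100000 nM, which is a limit and not a number.

Compound 4 `CC[C@@](C)(O)CC(=O)O[C@H](CC=C(C)C)C1=CC(=O)c2c(O)ccc(O)c2C1=O` differs from it by 1-hydroxy-1-methylpropyl in place of 1-hydroxy-1-methylheptyl on a saturated chain carbon bound to a carbonyl carbon. Compound 2 `CC[C@](C)(O)CC(=O)O[C@H](CC=C(C)C)C1=CC(=O)c2c(O)ccc(O)c2C1=O` carries the same 1-hydroxy-1-methylpropyl group, with the opposite configuration at the defined stereocentre, and gives 20500 nM.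

The measured step closest to this change runs the other way: an at least 4.8-fold higher number from compound 2 to compound 3 (0.68 log units; beyond the scatter). It lies beyond the scatter, but it is bounded on one side only. Compound 1 `CC(=O)OCCO[C@H](CC=C(C)C)C1=CC(=O)c2c(O)ccc(O)c2C1=O` gives 15500 nM, and a 1.3-fold higher number from compound 1 to compound 2 (0.12 log units; within the scatter) lies within the scatter, so these two readings cannot be told apart. Among the measured compounds shown here, no measured pair isolates the configuration at the stereocentre, which leaves the main uncertainty there.

Shortening the chain is therefore expected to lower the number by a step of at least similar size, bringing compound 4 into the region of compound 1 and compound 2. The estimate means an expected at least 5.0-fold lower number from compound 3 to compound 4 (0.69 log units; beyond the scatter). Compound 4 is estimated at 20000 nM, with an expected range of 8000 nM to 50000 nM.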

Compound 4, half-maximal inhibitory concentration: 12700 nM
For compound 4 the middle estimate is 1.6-fold (0.20 log units) above the measured one; the measured number falls inside the stated range.
By their numbers in this assay, from the lowest: compounds 4, 1 and 2 (each within the scatter of the next). At a limit, above all of these: compound 3.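

In this assay, 1-hydroxy-1-methylpropyl in place of 1-hydroxy-1-methylheptyl on a saturated chain carbon bound to a carbonyl carbon gives an at least 7.8-fold lower number from compound 3 to compound 4 (0.89 log units; beyond the scatter), a second short-chain comparison alongside the earlier one from compound 2, and still bounded on one side only, as compound 3 stands at a limit: the limit of > 100000 nM in this assay, at which 1 of the 4 values shown sits. Among the compounds shown here, the new pair also tests the configuration at the saturated chain carbon, which the earlier compounds left untested; a 1.6-fold lower number from compound 2 to compound 4 (0.21 log units; within the scatter) lies within the scatter, so the S and R forms cannot be told apart in this assay, in a clean comparison: the fact that compounds 2 and 4 differ only in the configuration as drawn. With a 1.2-fold lower number from compound 1 to compound 4 (0.09 log units; within the scatter) also within the scatter, the 2-acetoxyethyl compound cannot be told apart from either short-chain form.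

With only the 1-hydroxy-1-methylpropyl and 1-hydroxy-1-methylheptyl groups shown, the chain length at which the number starts to rise stays open, as does the true size of the step to compound 3. Also open, on these data alone, are whether an amine or a carboxylic acid at this place would hold the number in this range, and whether configuration counts with the longer chain.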